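A Boronic Acid in Place of a Carboxymethoxy Group

The source may hold more compounds than are shown below. What is called first, only, known or untested is meant among the compounds shown, and "the series" means these compounds.

Compound 1, `O=C(/C=C/c1ccc(F)c(Cl)c1)c1ccc(B(O)O)cc1`: 25000 nM
Compound 2, `O=C(O)COc1ccc(C(=O)/C=C/c2ccc(Cl)c(Cl)c2)cc1`: 13000 nM

Of the compounds shown here, two have been measured in a functional assay on MCF-10A cells (Homo sapiens) for inhibition; a lower number here means a stronger inhibitor, a higher number a weaker inhibitor. Compound 1 gives 25000 nM in this assay, and compound 2 gives 13000 nM. Compound 2 thus holds the lowest of the two numbers, but its nearest neighbour, compound 1, sits within the usual scatter of it, so the two values cannot be placed in any order.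

Compound 3, `O=C(/C=C/c1ccc(Cl)c(Cl)c1)c1ccc(B(O)O)cc1`, has not yet been measured. It differs from compound 2 in one place: a group of 3 heavy atoms (1 boron, 2 oxygen; no ring) in place of a group of 5 heavy atoms (2 carbon, 3 oxygen; no ring), on an aromatic carbon. Within the data shown here, no measured pair shows this exact exchange. Compound 1 carries the same entering group on a closely related core and gives 25000 nM, which does not stand beyond the scatter from compound 2. The step from compound 2 to compound 3 in this assay is therefore expected to be small, a 1.5-fold higher number from compound 2 to compound 3 (0.19 log units; within the scatter), leaning slightly towards a weaker inhibitor but not clearly beyond the scatter. Compound 3 is estimated at 20000 nM, with a range from 8000 nM to 50000 nM.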

Compound 3, half-maximal inhibitory concentration: 18000 nM
For compound 3 the middle estimate is 1.1-fold (0.05 log units) above the measured one; the range from low to high includes it.
By their numbers in this assay, from the lowest: compounds 2, 3 and 1 (each within the scatter of the next).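

Among these compounds, compound 3 gives the first direct comparison at this position. In this assay, putting the boronic acid in place of the carboxymethoxy group, on an aromatic carbon para to a large group, gives a 1.4-fold higher number from compound 2 to compound 3 (0.14 log units; within the scatter), so the two groups cannot be told apart in this cell read-out, even though they differ in size and in their count of hydrogen-bond donors. Compound 3 also ties compound 1 to the same comparison: chloro in place of fluoro on an aromatic carbon gives a 1.4-fold lower number from compound 1 to compound 3 (0.14 log units; within the scatter), so this second exchange cannot be told apart from the scatter either, and no measurement at hand bears on why these numbers lie so close.

The compounds shown leave open whether any other group at this position, such as a carboxylic acid, an amine or a longer chain, would move the number beyond the scatter. They also leave open whether the exchange of fluoro for chloro would read the same with the carboxymethoxy group in place, and whether this flat picture in this assay extends to other cells.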